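The source may report more compounds than this note shows. Statements on the series, on what has been measured and on what is new or still open speak of the compounds shown alone.

Of the compounds shown here, three of one series have been measured so far, each carrying the same core and a long chain that ends in a positively charged group, and they differ from one another in more than one place at a time. In an assay on LX2 cells for inhibition of COL1A1 promoter (Homo sapiens), read by a luciferase reporter, with a stated time of 24 h, tested at 20 uM (on this read-out higher numbers stand for a stronger effect at the one concentration tested and lower numbers for a weaker effect), compound 1 `CN(C)c1ccc2c(=O)c(C(=O)Nc3cc(F)cc(F)c3)cn(-c3ccc(OCCCCCCC[N+]45CCN(CC4)CC5)cc3F)c2n1` gives 9.02%. In this assay compound 2 `Cc1cc(OCCCCCCC[N+]23CCN(CC2)CC3)cc(-n2cc(C(=O)Nc3cc(F)cc(F)c3)c(=O)c3ccc(N(C)C)nc32)c1` gives 10.3%. In this assay compound 3 `Cc1cc(-n2cc(C(=O)Nc3cc(F)cc(F)c3)c(=O)c3ccc(N(C)C)nc32)ccc1OCCCCCCC[N+]1(C)CCCC1` gives 26.1%, which is the highest of the three numbers: the gap to compound 2, the nearest, lies beyond the usual scatter, and the gap to compound 1, the furthest, lies beyond it as well.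

Compound 4 `Cc1cc(-n2cc(C(=O)Nc3cc(F)cc(F)c3)c(=O)c3ccc(N(C)C)nc32)ccc1OCCCCCCC[n+]1ccccc1` is not yet measured. It is built from compound 3 by one change, (a group of 6 heavy atoms (5 carbon, 1 nitrogen; one six-membered aromatic ring with 1 hetero atom) in place of a group of 6 heavy atoms (5 carbon, 1 nitrogen; one five-membered non-aromatic ring with 1 hetero atom), on a saturated chain carbon, seven bonds along the chain from an oxygen on an aromatic ring). Going by the values given here, no measured pair of compounds differs in only one place, so nothing is known about how large a step such a change brings in this assay. The expectation is a step of a number 5.1 percentage points lower from compound 3 to compound 4 (within the scatter), that is, either no change beyond the scatter or a modest fall. Compound 4 is therefore estimated to give 21% in this assay, with a range from 7% to 36%.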

Compound 4, a percentage reported as inhibition, at one concentration (the size of the read-out at that concentration, not a potency): "not active" (no number reported)
For compound 4 the study gives words and no number; there is nothing to compare the estimate with.
By their numbers in this assay, from the lowest: compounds 1 and 2 (each within the scatter of the next); then compound 3.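

Going by these compounds alone, compound 4 is reported in words only, without a number, so no step from compound 3 to compound 4 can be read. On these data alone, how large an effect this ring exchange has remains open, and no supporting data here bear on the result.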